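This account rests on a few compounds, and the source may have more. Where it says the series, first, only, none or still open, it means among the compounds named here.

Measured in a functional assay on KYSE-520 cells for antiproliferative activity against KYSE-520 cell line (Homo sapiens), read by CellTiter-Glo, with a stated time of 24 h; on this read-out lower numbers stand for stronger inhibition and higher numbers for weaker inhibition:
- compound 1 `C[C@@H]1OCC2(CCN(c3cnc4c(-c5cccc(Cl)c5Cl)n[nH]c4n3)CC2)[C@@H]1N`: 460 nM
- compound 2 `C[C@@H]1OCC2(CCN(c3nc4[nH]nc(Sc5ccnc(N)c5Cl)c4c(=O)n3C)CC2)[C@@H]1N`: 720 nM
- compound 3 `Cc1nc(N)ccc1-c1n[nH]c2nc(N3CCC4(CC3)CO[C@@H](C)[C@H]4N)n(C)c(=O)c12`: 660 nM

Compound 2 lies within the scatter of both other compounds, so these values set no order among the three. Compound 4 `C[C@@H]1OCC2(CCN(c3nc4[nH]nc(-c5ccnc(N)c5Cl)c4c(=O)n3C)CC2)[C@@H]1N` differs from compound 2 as follows: 2-amino-3-chloropyridin-4-yl in place of (2-amino-3-chloropyridin-4-yl)sulfanyl on an aromatic carbon. Among the compounds with values here, the one measured step that bears on this is a 1.1-fold lower number from compound 2 to compound 3 (0.04 log units; within the scatter). There, 6-amino-2-methylpyridin-3-yl likewise replaces the same sulfanyl group on an aromatic carbon. A change beyond the scatter is therefore not expected in this assay. The expected step is a 1.2-fold lower number from compound 2 to compound 4 (0.08 log units; within the scatter). The estimate for compound 4 is 600 nM, with an expected range of 250 nM to 1400 nM.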

Compound 4, half-maximal inhibitory concentration: 1200 nM
The estimate for compound 4 lay 2.0-fold (0.30 log units) below the measured number, and the stated range covers the measured number.
By their numbers in this assay, from the lowest: compounds 1, 3, 2 and 4 (each within the scatter of the next, the first and the last beyond it).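

At this aromatic carbon of the five-membered ring, 2-amino-3-chloropyridin-4-yl in place of its sulfanyl-linked counterpart gives a step within the scatter in this assay (a 1.7-fold higher number from compound 2 to compound 4 (0.22 log units; within the scatter)), so this read-out does not separate the sulfur-linked group from the directly attached one. Exchanging 6-amino-2-methylpyridin-3-yl for 2-amino-3-chloropyridin-4-yl at the same carbon also stays within the scatter (a 1.8-fold higher number from compound 3 to compound 4 (0.26 log units; within the scatter)). No measurement at hand offers an explanation for these steps. From the compounds shown here alone, whether a small primary amine or a longer alkyl chain at this carbon would give a step beyond the scatter remains open.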